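A few compounds are considered here, and "the series" means these few. Any claim that something is new, unique, unknown or untested is made for them only; others in the source may bear on it.

Working notes on the series, step from compound 3 to compound 4.

Three compounds of the shared core have numbers in an ADME assay on cells (Hepatocyte, Rattus norvegicus) for metabolic stability, read by HPLC, with a stated time of 30 min, tested at 1 uM; on this read-out lower numbers stand for slow clearance and higher numbers for fast clearance. Compound 1 `COCc1ccc(-c2ccc3nnc(C(N)=O)c(N[C@@H](C)C4CCOCC4)c3c2)cn1` gives 5.6 uL/min. Compound 2 `COCc1ccc(-c2ccc3nnc(C(N)=O)c(N[C@@H](C)c4ccn(C)n4)c3c2)cn1` gives 4.9 uL/min. Compound 3 `C[C@H](Nc1c(C(N)=O)nnc2ccc(-c3ccc(OCCCN(C)C)nc3)cc12)C1CCOCC1` gives 3.4 uL/min. Compound 3 has the lowest of the three numbers, but its gaps to compound 2 and to compound 1 are both within the scatter, so the three compounds cannot be set apart from one another on this read-out.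

Compound 4 `C[C@H](Nc1c(C(N)=O)nnc2ccc(-c3ccc(OCCCN(C)C)nc3)cc12)c1ccn(C)n1` has not been measured. It differs from compound 3 in one place: 1-methyl-1H-pyrazol-3-yl in place of oxan-4-yl on a saturated chain carbon bound to a nitrogen on an aromatic ring and a saturated chain carbon

The same change has been made once already in the series, from compound 1 to compound 2, where it gave a 1.1-fold lower number from compound 1 to compound 2 (0.06 log units; within the scatter). The other measured step, a 1.6-fold lower number from compound 1 to compound 3 (0.22 log units; within the scatter), concerns the other point of variation and only fixes where compound 3 starts. On this basis no step beyond the scatter is expected for compound 4 in this assay; the estimated step is a 1.1-fold lower number from compound 3 to compound 4 (0.04 log units; within the scatter). For compound 4 the number in this assay is expected to be 3.1 uL/min, with a range from 1.6 uL/min to 6.2 uL/min.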

Compound 4, intrinsic clearance in a liver preparation (reported as CLH), per the amount of preparation that the assay uses: 7 uL/min
Estimate against measurement, compound 4: 2.3-fold (0.35 log units) below; the whole stated range lies below it.
By their numbers in this assay, from the lowest: compounds 3, 2, 1 and 4 (each within the scatter of the next, the first and the last beyond it).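

In this assay, for the compounds shown here, the change to 1-methyl-1H-pyrazol-3-yl from oxan-4-yl on this saturated chain carbon now gives a step beyond the scatter with 3-(dimethylamino)propoxy on the aromatic carbon, a 2.1-fold higher number from compound 3 to compound 4 (0.31 log units; beyond the scatter), whereas its one earlier reading, with methoxymethyl there, lay within the scatter. Even so, the two readings of this change cannot be set apart, so no dependence on the group at the aromatic carbon is shown: the same change on two cores in this assay, a 1.1-fold lower number (0.06 log units; within the scatter) from compound 1 to compound 2 and a 2.1-fold higher number (0.31 log units; beyond the scatter) from compound 3 to compound 4, 2.4-fold (0.37 log units) apart, within the scatter of two such steps. Going by these compounds alone, the change from methoxymethyl to 3-(dimethylamino)propoxy, read for the first time with 1-methyl-1H-pyrazol-3-yl in place, gives a 1.4-fold higher number from compound 2 to compound 4 (0.15 log units; within the scatter), and this reading also cannot be set apart from the earlier one: the same change on two cores in this assay, a 1.6-fold lower number (0.22 log units; within the scatter) from compound 1 to compound 3 and a 1.4-fold higher number (0.15 log units; within the scatter) from compound 2 to compound 4, 2.4-fold (0.37 log units) apart, within the scatter of two such steps.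

Within the data shown here, with only two readings of each change, it remains open whether the two points of variation act independently of each other in this assay. Also open, going by these compounds, is how a piperidin-4-yl group on the same saturated chain carbon, or a shorter 2-(dimethylamino)ethoxy chain on the aromatic carbon, would read in this assay.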